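Notes on removing the (prop-1-en-1-yl)carbonyl group

The compounds below may be only part of what the source reports. "The series", "measured", "known", "first", "only" and "open" are said of these compounds alone.

Of the compounds shown here, three on one shared core have been measured in a functional assay on MGC-803 cells (Homo sapiens) for inhibition, read by MTT assay, with a stated time of 48 h; a higher number here means a weaker inhibitor, a lower number a stronger inhibitor. Compound 2 `C/C=C/C(=O)N(Cc1ccc(OC)cc1)c1cc(OC)c(OC)c(OC)c1` gives 450 nM and stands lowest of the three numbers. Compound 3 `C/C=C/C(=O)N(Cc1ccc(OC)c(F)c1)c1cc(OC)c(OC)c(OC)c1` gives 1650 nM; its core differs from that of compound 2 as hydrogen in place of fluoro on an aromatic carbon, and the step is a 3.7-fold higher number from compound 2 to compound 3 (0.56 log units; beyond the scatter). Compound 1 `COc1ccc(CNc2cc(OC)c(OC)c(OC)c2)cc1F` gives 39700 nM, the highest number in the set.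

The change from compound 3 to compound 1 is hydrogen in place of (prop-1-en-1-yl)carbonyl on a nitrogen on an aromatic ring, and it produced a 24-fold higher number from compound 3 to compound 1 (1.38 log units; beyond the scatter). Compound 4 `COc1ccc(CNc2cc(OC)c(OC)c(OC)c2)cc1` is not yet measured; it differs from compound 2 by hydrogen in place of (prop-1-en-1-yl)carbonyl on a nitrogen on an aromatic ring. The two place descriptions read the same word for word, so this is the same change, occurring twice in all among the compounds here, once measured and once open. The only difference between the two settings is the one in the cores noted above.

Within the data shown here, with a single prior instance, the expected step is a 24-fold higher number from compound 2 to compound 4 (1.38 log units; beyond the scatter), resting on a 24-fold higher number from compound 3 to compound 1 (1.38 log units; beyond the scatter) as the sole guide, with the gap between compound 2 and compound 3 in this assay taken as not altering the size of the step. Compound 4 is therefore expected at about 10800 nM in this assay. The likely range for compound 4 is estimated as 3500 nM to 35000 nM, wide because only a 24-fold higher number from compound 3 to compound 1 (1.38 log units; beyond the scatter) supports the expectation.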

Compound 4, half-maximal inhibitory concentration: 11400 nM
Compound 4: the middle estimate sits 1.1-fold (0.02 log units) below what was measured, within the range that was stated.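

In this assay, hydrogen in place of (prop-1-en-1-yl)carbonyl on the nitrogen gives a 25-fold higher number from compound 2 to compound 4 (1.40 log units; beyond the scatter), so the step carries from the core bearing fluoro to the core without it at the same size within the scatter: the same change on two cores in this assay, a 24-fold higher number (1.38 log units; beyond the scatter) from compound 3 to compound 1 and a 25-fold higher number (1.40 log units; beyond the scatter) from compound 2 to compound 4, 1.1-fold (0.02 log units) apart, within the scatter of two such steps

The fluoro change also holds when the nitrogen carries hydrogen, where hydrogen in place of fluoro on an aromatic carbon gives a 3.5-fold lower number from compound 1 to compound 4 (0.54 log units; beyond the scatter), so across these four compounds the two changes combine without either altering the size of the other: the same change on two cores in this assay, a 3.7-fold higher number (0.56 log units; beyond the scatter) from compound 2 to compound 3 and a 3.5-fold higher number (0.54 log units; beyond the scatter) from compound 4 to compound 1, 1.1-fold (0.02 log units) apart, within the scatter of two such steps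

This shows transfer only between two cores that differ in one fluoro, and it does not show that the step keeps its size on a core changed elsewhere, nor which part of the removed group accounts for it.

The compounds shown leave open whether the double bond of the (prop-1-en-1-yl)carbonyl group matters, since a saturated butanoyl chain, a shorter acetyl or a sulfonyl group on the same nitrogen would separate that from the carbonyl alone. They also leave open whether the agreement between the two steps would survive with chloro or trifluoromethyl in place of fluoro.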